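The compounds below may be only part of what the source reports. "The series", "measured", "known", "first", "only" and "open" are said of these compounds alone.

Series, measured in a functional assay (trachea) for inhibition, with Cavia porcellus as the target; a higher number here means weaker binding, a lower number tighter binding:

compound 1, `COC(=O)c1ccccc1OCC(O)CNC(C)C` — 12.6 nM
compound 2, `COC(=O)c1ccccc1OCC(O)CNC(C)(C)C` — 1.26 nM
compound 3, `COC(=O)c1ccccc1OCC(O)CNCCNC(=O)C(C)C` — 31.6 nM

Compound 3 gives the highest number of the three: it stands above compound 1 by a 2.5-fold higher number from compound 1 to compound 3 (0.40 log units; beyond the scatter) and above compound 2 by a 25-fold higher number from compound 2 to compound 3 (1.40 log units; beyond the scatter), both beyond the scatter, so it is the weakest of the set. The other measured step is a 10-fold lower number from compound 1 to compound 2 (1.00 log units; beyond the scatter), where a methyl replaces a hydrogen on the saturated chain carbon bound to the amine nitrogen.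

Compound 4, `COC(=O)c1ccccc1OCC(O)CNCCNS(=O)(=O)N(C)C`, differs from compound 3 in one place: dimethylsulfamoyl in place of isopropylcarbonyl on an amine nitrogen. All three measured steps touch the substituent on the amine nitrogen of the shared core, not the group carried at the far end of the 2-aminoethyl chain, so none of them bears directly on this exchange. There is no measured ground for a step in either direction, and the working expectation is a change not beyond the scatter, no change at the digits printed from compound 3 to compound 4 (within the scatter). Compound 4 is therefore estimated at 31.6 nM, with a range of 10 nM to 100 nM.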

Compound 4, dissociation constant: 50.1 nM
The estimate for compound 4 lay 1.6-fold (0.20 log units) below the measured number; the measured number falls inside the stated range.
By their numbers in this assay, from the lowest: compound 2; then compound 1; then compounds 3 and 4 (each within the scatter of the next).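

The exchange on an amine nitrogen whose other neighbour is a saturated chain carbon gives a 1.6-fold higher number from compound 3 to compound 4 (0.20 log units; within the scatter) in this assay and is the first step shown at this nitrogen rather than at the nitrogen of the shared core. Going from isopropylcarbonyl, with 1 hydrogen-bond acceptor and no sulfur, to dimethylsulfamoyl, with 2 hydrogen-bond acceptors and a sulfur, therefore leaves no readable difference in this assay. No measurement at hand accounts for this outcome.

As far as these compounds go, how this nitrogen would read with a free amine, with a smaller acyl group such as acetyl, or with a methanesulfonyl group stays open. So does the effect of a longer chain in place of the 2-aminoethyl chain that carries these groups.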